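The compounds below may be only part of what the source reports. "The series", "measured", "known", "first", "only" and "open" are said of these compounds alone.

Compound 1 `CCCOC(=O)Nc1ccc([Se]C#N)cc1` shows the higher of the two numbers found in a functional assay on MCF7 cells (Homo sapiens) for cytotoxicity, read by MTT assay, with a stated time of 72 h (a higher number here means a weaker inhibitor of growth, a lower number a stronger inhibitor of growth), where compound 1 gives 8000 nM, though compound 2 `N#C[Se]c1ccc(NC(=O)Oc2ccc(Cl)cc2)cc1`, which gives 6000 nM, lies within the scatter of it, so no real order between the two can be read. Compound 3 `CCOC(=O)Nc1ccc([Se]C#N)cc1` differs from compound 1 by hydrogen in place of methyl on a saturated chain carbon, two bonds along the chain from an oxygen next to a carbonyl group, which also reads as propoxy to ethoxy. Going by the values given here, no measured pair shows a change of this kind, so the step of no change at the digits printed from compound 1 to compound 3 (within the scatter) is expected to stay within the scatter. Compound 3 is therefore estimated at 8000 nM, with a range from 4000 nM to 16000 nM.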

Compound 3, concentration for 50% growth inhibition: 8900 nM
Compound 3: the middle estimate sits 1.1-fold (0.05 log units) below what was measured; the measured number falls inside the stated range.
By their numbers in this assay, from the lowest: compounds 2, 1 and 3 (each within the scatter of the next).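

In this assay, going from propoxy to ethoxy gives a 1.1-fold higher number from compound 1 to compound 3 (0.05 log units; within the scatter). Going by these compounds alone, this is the first direct reading at this saturated chain carbon, and it shows that hydrogen in place of methyl there does not move the number beyond the scatter. No supporting measurement bears on this result, so it stands without explanation. From the compounds shown here alone, whether a longer chain such as butoxy, or a methoxy group, would also stay within the scatter remains open. So does whether an amine in place of the oxygen would.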